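What 3-ethynylphenyl may do in place of 3-chloro-2-fluorophenyl

A few compounds are considered here, and "the series" means these few. Any claim that something is new, unique, unknown or untested is made for them only; others in the source may bear on it.

In a functional assay on PC-3 cells (Homo sapiens) for antiproliferative activity, read by MTT assay, with a stated time of 48 h (a higher number here means a weaker inhibitor, a lower number a stronger inhibitor), compound 1 (`O=C(/C=C/c1ccccc1)Nc1cc2c(Nc3ccc(F)c(Cl)c3)ncnc2s1`) gives 700 nM and compound 2 (`O=C(/C=C/c1ccccc1)Nc1cc2c(Nc3cccc(Cl)c3F)ncnc2s1`) gives 400 nM. Among the measured compounds shown here, these two values lie within the scatter of each other, so compound 2 stands level with the only other measured compound. Compound 3 (`C#Cc1cccc(Nc2ncnc3sc(NC(=O)/C=C/c4ccccc4)cc23)c1`) keeps the shared core and differs from compound 2 in one place: 3-ethynylphenyl in place of 3-chloro-2-fluorophenyl on a nitrogen on an aromatic ring. For the measured compounds named here, one measured step bears on this place, a 1.8-fold lower number from compound 1 to compound 2 (0.24 log units; within the scatter), with 3-chloro-2-fluorophenyl in place of 3-chloro-4-fluorophenyl on a nitrogen on an aromatic ring. Going by the values given here, that step is small, but both of its groups carry chlorine and fluorine, and no measured compound has the triple bond outside aromatic rings. The data therefore give no direction for the new group, and no shift beyond the scatter is expected in this assay, although the range must stay wide. The expected size of the change is a 1.3-fold higher number from compound 2 to compound 3 (0.10 log units; within the scatter). Compound 3 is estimated at 500 nM, with an expected range from 170 nM to 1500 nM.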

Compound 3, half-maximal inhibitory concentration: 400 nM
Compound 3: the middle estimate sits 1.3-fold (0.10 log units) above what was measured, and the stated range covers the measured number.
By their numbers in this assay, from the lowest: compounds 2, 3 and 1 (each within the scatter of the next).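

In this assay, 3-ethynylphenyl in place of 3-chloro-2-fluorophenyl gives no change at the digits printed from compound 2 to compound 3 (within the scatter). The earlier pair had compared only groups carrying chlorine and fluorine, whereas this result shows that a phenyl group with neither halogen, bearing a triple bond outside aromatic rings instead, keeps the number level at this place on the nitrogen. The comparison with the other halogenated group reads the same way, with a 1.8-fold lower number from compound 1 to compound 3 (0.24 log units; within the scatter), so the three groups cannot be told apart in this assay, and no separate measurement is at hand to account for this level result.

All three groups are phenyl rings bearing only halogen or ethynyl substituents, so the compounds shown leave open how this position would respond to an amine or a carboxylic acid on that ring, or to a longer chain ending in the triple bond. The shared core and its amide side chain stay the same throughout, so they also leave open whether the level result would hold with a different group at that amide.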